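Swapping the aryl arm on the unsaturated linker

A few compounds are considered here, and "the series" means these few. Any claim that something is new, unique, unknown or untested is made for them only; others in the source may bear on it.

Compound 1 `CC(C)(C)c1ccc(CCC(=O)Nc2ccc3c(c2)OCCO3)cc1` gives 150 nM in a functional assay on CHO cells for inhibition of transient receptor potential cation channel subfamily V member 1 (Homo sapiens); a higher number here means a weaker inhibitor, a lower number a stronger inhibitor.
Compound 2 `CC(C)(C)c1ccc(C2CC2C(=O)Nc2ccc3c(c2)OCCO3)cc1` gives 1800 nM.
Compound 3 `CC(C)(C)c1ccc(/C(=C/C(=O)Nc2ccc3c(c2)OCCO3)c2ccncc2)cc1` gives 44 nM.

Compound 3 stands lowest of the three numbers in this assay; compound 1 comes nearest and compound 2 lies furthest away, both gaps beyond the usual scatter. Compound 4 `CCOC(=O)CC/C(=C\C(=O)Nc1ccc2c(c1)OCCO2)c1ccc(C(C)(C)C)cc1` differs from compound 3 in a single place: 2-(ethoxycarbonyl)ethyl in place of pyridin-4-yl on a double-bonded chain carbon bound to an aromatic carbon and a double-bonded chain carbon. Among the compounds with values here, no measured pair shows this exact change, so its size is open. Compound 1, which has a plain saturated linker with no side group, gives 150 nM, and a flexible ester chain is expected to land somewhere between that and compound 3. The change is expected to give a 4.5-fold higher number from compound 3 to compound 4 (0.66 log units; beyond the scatter), toward a weaker inhibitor. Compound 4 is estimated at 200 nM, within a range from 50 nM to 800 nM.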

Compound 4, half-maximal inhibitory concentration: 36 nM
For compound 4 the middle estimate is 5.6-fold (0.74 log units) above the measured one; measured number outside the range, below it.
By their numbers in this assay, from the lowest: compounds 4 and 3 (each within the scatter of the next); then compound 1; then compound 2.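

On this double-bonded chain carbon, a ring is not needed to keep the activity seen in this assay: putting the open-chain 2-(ethoxycarbonyl)ethyl in place of pyridin-4-yl gives a 1.2-fold lower number from compound 3 to compound 4 (0.09 log units; within the scatter). The two compounds therefore cannot be told apart in this assay, although one carries an aromatic ring here and the other an ester chain. Nothing measured here explains why the two groups match.

Going by these compounds, whether the ester matters remains open: a carboxylic acid or a plain propyl chain at this position could test that. On these data alone, the effect of a longer chain or an amine also remains unknown.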